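Aryl group change on the ring amine nitrogen

The compounds below may be only part of what the source reports. "The series", "measured", "known", "first", "only" and "open" are said of these compounds alone.

Three compounds of the series have a reading in a functional assay on CHO cells with adenosine receptor A1 (Homo sapiens) as the target, read by cAMP accumulation and immunoassay, with a stated time of 6 min, tested at 0.01 uM; a lower number here means a stronger effect, a higher number a weaker effect of the compound at the concentration tested. Compound 1 `Nc1scc(CN2CCN(c3ccc(Cl)cc3F)CC2)c1C(=O)c1ccc(Cl)cc1` gives -9.2%. Compound 2 `Nc1scc(CN2CCN(c3ccccc3C(F)(F)F)CC2)c1C(=O)c1ccc(Cl)cc1` gives 0%, and compound 3 `Nc1scc(CN2CCN(c3c(F)cccc3F)CC2)c1C(=O)c1cccc(C(F)(F)F)c1` gives 2.1%. Compound 2 thus holds the second highest of the three numbers; its nearest neighbour is compound 3, its furthest compound 1, and both gaps are within the scatter, so no order among the three can be read from them.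

The next compound, compound 4 `Nc1scc(CN2CCN(c3ccc(F)cc3F)CC2)c1C(=O)c1ccc(Cl)cc1`, is not yet measured in this assay. It differs from compound 2 in one place: 2,4-difluorophenyl in place of 2-(trifluoromethyl)phenyl on an amine nitrogen in a ring.

For the measured compounds named here, only one measured step bears on this change. It is the exchange of the aryl group on the same ring amine nitrogen, a number 9.2 percentage points higher from compound 1 to compound 2 (within the scatter), which stayed within the scatter. Compound 3 carries a different aryl group on that nitrogen as well, but it also differs elsewhere, so only its number itself is informative, and that number sits near the other two. Nothing in the series suggests that another aryl group here moves the reading beyond the scatter.

The expected step is therefore a number 3 percentage points lower from compound 2 to compound 4 (within the scatter), a flat result. Compound 4 is estimated at -3%, within -15% to 10%.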

Compound 4, a percentage reported as activity, at one concentration (the size of the read-out at that concentration, not a potency): 0%
For compound 4 the middle estimate is 3 percentage points below the measured one; low and high end bracket the measured number.
By their numbers in this assay, from the lowest: compounds 1, 2, 4 and 3 (each within the scatter of the next, the first and the last beyond it).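

With the rest of the molecule unchanged, a second aryl exchange on the ring amine nitrogen in this assay, no change at the digits printed from compound 2 to compound 4 (within the scatter), stays within the scatter, so 2-(trifluoromethyl)phenyl and 2,4-difluorophenyl cannot be told apart at this position. The series also gains its first comparison of a single halogen on this aryl group, a number 9.2 percentage points higher from compound 1 to compound 4 (within the scatter), and 4-chloro-2-fluorophenyl and 2,4-difluorophenyl likewise cannot be told apart, so all three aryl groups on this nitrogen that can be compared directly give readings within the scatter of each other, although compounds 1 and 3 differ in more than one place and are not compared with each other. No measurement is available that accounts for these flat readings.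

All the aryl groups shown carry fluoro, chloro or trifluoromethyl, so the reading with an unsubstituted phenyl, a methoxyphenyl, a pyridine ring or a simple alkyl chain on this nitrogen remains open. Readings at one concentration also leave the potency of these compounds open, including whether any difference among them would appear at other concentrations.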